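The compounds below may be only part of what the source reports. "The series", "measured", "known", "first", "only" and "open" are said of these compounds alone.

Compound 1, `COc1cc2ncnc(NCc3cccc(NC(=O)Nc4ccc(C)cc4)c3)c2cc1OC`: 12900 nM
Compound 2, `COc1ccccc1NC(=O)Nc1cccc(CNc2ncnc3cc(OC)c(OC)cc23)c1`: 15200 nM
Compound 3, `COc1ccc(NC(=O)Nc2cccc(CNc3ncnc4cc(OC)c(OC)cc34)c2)cc1`: 24500 nM

Of the compounds shown here, three sharing one core have been measured in a functional assay on A549 cells (Homo sapiens) for antiproliferative activity, read by MTT assay; on this read-out lower numbers stand for stronger inhibition and higher numbers for weaker inhibition. Compound 3 returns the highest of the three numbers, yet it is not set apart from the others: the step of a 1.9-fold higher number from compound 1 to compound 3 (0.28 log units; within the scatter) and the step of a 1.6-fold higher number from compound 2 to compound 3 (0.21 log units; within the scatter) both stay within the scatter, as does the step of a 1.2-fold higher number from compound 1 to compound 2 (0.07 log units; within the scatter) between the two other compounds. On the numbers shown, the three compounds are indistinguishable.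

Compound 4, `COc1cc2ncnc(NCc3cccc(NC(=O)Nc4ccc(C(C)(C)C)cc4)c3)c2cc1OC`, has not yet been measured in this assay. Relative to compound 3 the change is tert-butyl in place of methoxy on an aromatic carbon. Within the data shown here, the only measured step at the same aromatic carbon is a 1.9-fold higher number from compound 1 to compound 3 (0.28 log units; within the scatter), in which a methyl became a methoxy and the number moved only within the scatter. The remaining steps, which alter the substitution pattern on that same phenyl ring, were also within the scatter. No measured step gives a reason to expect a change beyond the scatter, so compound 4 is expected to land near compound 1 and compound 3, with the step of a 1.6-fold lower number from compound 3 to compound 4 (0.21 log units; within the scatter) estimated to be small. For compound 4 the estimate in this assay is 15000 nM, with a range from 7000 nM to 32000 nM.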

Compound 4, half-maximal inhibitory concentration: 5210 nM
For compound 4 the middle estimate is 2.9-fold (0.46 log units) above the measured one; the whole stated range lies above it.
By their numbers in this assay, from the lowest: compound 4; then compounds 1, 2 and 3 (each within the scatter of the next).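

In this assay, the aromatic carbon para to a large group had looked insensitive while only methyl and methoxy were compared there, but it does respond to the group it carries: tert-butyl in place of methoxy gives a 4.7-fold lower number from compound 3 to compound 4 (0.67 log units; beyond the scatter), and tert-butyl in place of methyl gives a 2.5-fold lower number from compound 1 to compound 4 (0.39 log units; beyond the scatter), both beyond the scatter. The 4-(tert-butyl)phenyl group also separates from the 2-methoxyphenyl group, with a 2.9-fold lower number from compound 2 to compound 4 (0.47 log units; beyond the scatter), so compound 4 stands apart from the three earlier compounds, which could not be told from one another and gave no sign that this series could move at all. Nothing shown here accounts for this shift.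

The compounds shown leave open whether the number keeps falling with other groups on this carbon, such as an isopropyl, a cyclohexyl or a phenyl ring, or whether an amine or a carboxylic acid there would reverse the change. They also leave open whether the tert-butyl step holds on any cell line other than the one used in this assay.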